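The source may hold more compounds than are shown below. What is called first, only, known or untested is meant among the compounds shown, and "the series" means these compounds.

Measured in an assay for inhibition of ribonucleoside-diphosphate reductase RR1 (Homo sapiens), with a stated time of 30 min; on this read-out higher numbers stand for weaker inhibition and lower numbers for stronger inhibition:
Compound 1 `Oc1ccc(/C=N/NC(=S)Nc2ccccc2)cc1` gives 242000 nM.
Compound 2 `Oc1ccc(/C=N/NC(=S)Nc2ccccc2Cl)cc1` gives 46800 nM.
Compound 3 `Cc1cccc(NC(=S)N/N=C/c2ccc(O)cc2)c1` gives 30400 nM.

Compound 1 stands at the highest number of the three in this assay. The nearest is compound 2, reached by a 5.2-fold lower number from compound 1 to compound 2 (0.71 log units; beyond the scatter); the furthest is compound 3, reached by an 8.0-fold lower number from compound 1 to compound 3 (0.90 log units; beyond the scatter). Compound 4 `Oc1ccc(/C=N/NC(=S)Nc2ccc(O)cc2)cc1` differs from compound 1 by hydroxy in place of hydrogen on an aromatic carbon. Neither measured step carries a hydroxy group, so the bearing is indirect; both show that a substituent on that ring of compound 1 lowered the number modestly. A hydroxy group brings a donor and an acceptor rather than chloro or methyl, so the expected step is smaller and less certain: a 2.2-fold lower number from compound 1 to compound 4 (0.34 log units; beyond the scatter). Compound 4 is therefore estimated at 110000 nM, within a range of 35000 nM to 350000 nM.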

Compound 4, half-maximal inhibitory concentration: 43300 nM
Beside the measured number, compound 4's estimate is 2.5-fold (0.40 log units) above it; the measured number falls inside the stated range.
By their numbers in this assay, from the lowest: compounds 3, 4 and 2 (each within the scatter of the next); then compound 1.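

Hydroxy para to a large group brings a 5.6-fold lower number from compound 1 to compound 4 (0.75 log units; beyond the scatter) and so shows that the lowering on this ring is not confined to chloro and methyl: it also occurs with a group carrying a hydrogen-bond donor and acceptor. In this assay compound 3, compound 4 and compound 2 lie within the scatter of their neighbours in the order, so these three substituents are not separated. Nothing given here explains the step.

As far as these compounds go, whether an amine or a carboxylic acid at this place would lower the number as well remains open.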